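Purine benzamide series: notes on compound 4

A few compounds are considered here, and "the series" means these few. Any claim that something is new, unique, unknown or untested is made for them only; others in the source may bear on it.

Measured so far in a functional assay on NCI-H460 cells (Homo sapiens) for antiproliferative activity, read by CCK-8 assay, with a stated time of 72 h, tested at 2 uM; on this read-out lower numbers stand for a weaker effect and higher numbers for a stronger effect at the one concentration tested:

Compound 1 `COC(CCn1cnc2c(NCc3ccc(C(=O)Nc4ccccc4N)cc3)nc(Cl)nc21)OC` gives 43.7%.
Compound 2 `Nc1ccccc1NC(=O)c1ccc(Cn2cnc3c(NCc4ccccc4)nc(Cl)nc32)cc1` gives 44.7%.
Compound 3 `CCCCn1cnc2c(Nc3ccccc3)nc(NCOCc3ccc(C(=O)Nc4ccccc4N)cc3)nc21` gives 27.7%.

Compound 2 has the highest of the three numbers. Its nearest neighbour is compound 1, whose number lies lower but within the scatter, so the two cannot be placed in an order. The furthest is compound 3, whose number lies lower by a gap beyond the scatter; compound 3 is the weaker of the pair. Going by the values given here, no two of the measured compounds differ in a single place, so no step between them can be stated.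

The next compound to be measured is compound 4 `CN1CCN(c2nc(Cl)nc3c2ncn3Cc2ccc(C(=O)Nc3ccccc3N)cc2)CC1`. Relative to compound 2 it carries one change: 4-methylpiperazin-1-yl in place of benzylamino on an aromatic carbon. The rest of the core, the chloro group and the benzamide bearing the aminophenyl amide hydrogen are kept.

Among the compounds with values here, no measured pair shows this exchange, so the size of the step cannot be drawn from the series. The expectation is a step from compound 2 to compound 4 of a number 6.7 percentage points lower from compound 2 to compound 4 (within the scatter) in this assay, that is, no change beyond the scatter, with a slight lean downward. For compound 4 the estimated value in this assay is 38%, expected between 20% and 56%.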

Compound 4, a percentage reported as inhibition, at one concentration (the size of the read-out at that concentration, not a potency): 13.5%
The estimate for compound 4 lay 24.5 percentage points above the measured number; the measured number lies below the stated range.
By their numbers in this assay, from the lowest: compound 4; then compound 3; then compounds 1 and 2 (each within the scatter of the next).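

In this assay, going by these compounds alone, placing 4-methylpiperazin-1-yl in place of benzylamino on this aromatic carbon gives a number 31.2 percentage points lower from compound 2 to compound 4 (beyond the scatter), the first step that can be read, and it shows that the read-out is sensitive to the group at this position. The exchange removes both the six-membered aromatic ring of carbon only and the hydrogen-bond donor of benzylamino, and this single step cannot separate the two differences. No available evidence bears on the reason for the step.

Still open, from the compounds shown here alone, is which difference carries the step: cyclohexylmethylamino would keep the donor without the aromatic ring, while N-benzyl-N-methylamino would keep the aromatic ring without the donor. Going by these compounds, whether the step holds at other concentrations also remains open, since the read-out comes from one concentration.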